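Moving a chlorine on the pyridinyl amide

The source may report more compounds than this note shows. Statements on the series, on what has been measured and on what is new or still open speak of the compounds shown alone.

Measured compounds:
compound 1, `Cc1noc(C)c1-c1cnc(N)c(Oc2ccc(C(=O)Nc3ncccc3Cl)cc2)n1`, 27200 nM
compound 2, `Cn1cc(-c2cnc(N)c(Oc3ccc(C(=O)Nc4cc(Cl)ccn4)cc3)n2)cn1`, > 100000 nM

In a functional assay on HepG2 cells (Homo sapiens) for inhibition, read by MTT assay, with a stated time of 72 h (a higher number here means a weaker inhibitor, a lower number a stronger inhibitor), compound 1 gives 27200 nM. Compound 2 reaches only the limit of the assay, > 100000 nM, so no number is known for it; this is the point described by the limit of > 100000 nM in this assay, at which 1 of the 2 values shown sits. Compound 3, `Cn1cc(-c2cnc(N)c(Oc3ccc(C(=O)Nc4ncccc4Cl)cc3)n2)cn1`, is not yet measured. It differs from compound 2 by 3-chloropyridin-2-yl in place of 4-chloropyridin-2-yl on an amide-type nitrogen. For the measured compounds named here, no measured pair shows this change directly; compound 1 carries the same 3-chloropyridin-2-yl group as compound 3 but on a different core, and it gives a finite value in this assay. The step from compound 2 to compound 3 is therefore expected to bring the value back within the measurable range, an at least 2.0-fold lower number from compound 2 to compound 3 (0.30 log units; that floor lies within the scatter), a change that would be beyond the usual scatter. Compound 3 is estimated at 50000 nM, with a range of 15000 nM to 200000 nM.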

Compound 3, half-maximal inhibitory concentration: 21700 nM
For compound 3 the middle estimate is 2.3-fold (0.36 log units) above the measured one; low and high end bracket the measured number.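

In this assay, for the compounds shown here, 3-chloropyridin-2-yl in place of 4-chloropyridin-2-yl on the amide-type nitrogen gives an at least 4.6-fold lower number from compound 2 to compound 3 (0.66 log units; beyond the scatter), the first direct reading of where the chlorine sits on this group. That step gives only a floor, and the value of compound 2 is a limit: the limit of > 100000 nM in this assay, at which 1 of the 3 values shown sits. With 3-chloropyridin-2-yl held fixed, the exchange on the core gives a 1.3-fold lower number from compound 1 to compound 3 (0.10 log units; within the scatter), so 1-methyl-1H-pyrazol-4-yl and 3,5-dimethyl-1,2-oxazol-4-yl are not told apart here.

The compounds shown leave open what a fluorine, a methyl or a methoxy group would give in place of the chlorine of 3-chloropyridin-2-yl. They also leave open whether 4-chloropyridin-2-yl would behave the same way on the core of compound 1.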